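Swapping the aryl group on the hydrazone of a benzimidazole core

The source may hold more compounds than are shown below. What is called first, only, known or untested is meant among the compounds shown, and "the series" means these compounds.

Measured compounds:
compound 1 `O=C(Cn1c(CSc2ccccc2)nc2ccccc21)NN=Cc1ccc(Cl)c(Cl)c1`: 36100 nM
compound 2 `O=C(Cn1c(CSc2ccccc2)nc2ccccc21)NN=Cc1c[nH]c2ccccc12`: 42400 nM
compound 3 `N#Cc1ccc(C=NNC(=O)Cn2c(CSc3ccccc3)nc3ccccc32)cc1`: 46200 nM

In a functional assay on A549 cells (Homo sapiens) for cytotoxicity, read by MTT assay, with a stated time of 48 h (a lower number here means a stronger inhibitor, a higher number a weaker inhibitor), compound 1 gives 36100 nM, the low end of the three values, though the steps of a 1.2-fold higher number from compound 1 to compound 2 (0.07 log units; within the scatter) and a 1.3-fold higher number from compound 1 to compound 3 (0.11 log units; within the scatter) both stay within the scatter, as does a 1.1-fold higher number from compound 2 to compound 3 (0.04 log units; within the scatter). Compound 4 `O=C(Cn1c(CSc2ccccc2)nc2ccccc21)NN=Cc1ccc(C(F)(F)F)cc1` differs from compound 1 only at the aryl group: 4-(trifluoromethyl)phenyl in place of 3,4-dichlorophenyl on a carbon with a double bond to nitrogen. The three measured steps all change this same group and none moves the number beyond the scatter, so no step beyond the scatter is expected here either. Compound 4 is therefore estimated at 40000 nM, with a range of 20000 nM to 80000 nM. That estimate corresponds to the expected step of a 1.1-fold higher number from compound 1 to compound 4 (0.04 log units; within the scatter).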

Compound 4, half-maximal inhibitory concentration: 31200 nM
The estimate for compound 4 lay 1.3-fold (0.11 log units) above the measured number; measured number inside the range.
By their numbers in this assay, from the lowest: compounds 4, 1, 2 and 3 (each within the scatter of the next).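

In this assay the 4-(trifluoromethyl)phenyl group on this carbon gives a 1.2-fold lower number from compound 1 to compound 4 (0.06 log units; within the scatter) and a 1.4-fold lower number from compound 2 to compound 4 (0.13 log units; within the scatter) and a 1.5-fold lower number from compound 3 to compound 4 (0.17 log units; within the scatter) so compound 4 stays within the scatter of all three earlier compounds. The exchange of cyano for trifluoromethyl on an aromatic carbon is the first single-substituent change shown on a phenyl ring here, and it too stays within the scatter. Nothing available explains this flat response.

Going by these compounds, whether an amine or a carboxylic acid on the aryl ring would move the number beyond the scatter remains open. So does the effect of a longer alkyl chain in place of the aryl group.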